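This account rests on a few compounds, and the source may have more. Where it says the series, first, only, none or still open, it means among the compounds named here.

In a functional assay on SK-OV-3 cells (Homo sapiens) for cytotoxicity, read by sulforhodamine B assay, with a stated time of 48 h (a higher number here means a weaker inhibitor, a lower number a stronger inhibitor), compound 1, `O=c1cc(-c2ccccc2)oc2cc(OCCCCNc3nc4ccccc4s3)cc(O)c12`, gives 48.5 ug/mL. Compound 2, `O=c1cc(-c2ccccc2)oc2cc(OCCCCNc3nc4ccc(Br)cc4s3)cc(O)c12`, gives 35.1 ug/mL in this assay. Its number is the lower of the two shown, but the step of a 1.4-fold lower number from compound 1 to compound 2 (0.14 log units; within the scatter) lies within the usual scatter of repeated measurements, so on these numbers the two compounds cannot be told apart. Compound 3, `O=c1cc(-c2ccccc2)oc2cc(OCCCCNc3nc4ccc(I)cc4s3)cc(O)c12`, has not yet been measured in this assay. It differs from compound 2 by iodo in place of bromo on an aromatic carbon. Among the measured compounds shown here, the only measured step that bears on this position is a 1.4-fold lower number from compound 1 to compound 2 (0.14 log units; within the scatter), which put bromo where hydrogen had been and stayed within the scatter. Exchanging bromo for iodo at the same position gives no ground in these data to expect a step beyond the scatter in this assay. Compound 3 is therefore expected to give about 30 ug/mL, within a range of 15 ug/mL to 60 ug/mL. The estimated step of a 1.2-fold lower number from compound 2 to compound 3 (0.07 log units; within the scatter) is expected to be small.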

Compound 3, half-maximal inhibitory concentration: 56.4 ug/mL
Compound 3: the middle estimate sits 1.9-fold (0.27 log units) below what was measured, and the stated range covers the measured number.
By their numbers in this assay, from the lowest: compounds 2, 1 and 3 (each within the scatter of the next).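

With iodo at this place, this assay now has three groups to compare on the same aromatic carbon, and neither new step leaves the scatter (a 1.6-fold higher number from compound 2 to compound 3 (0.21 log units; within the scatter); a 1.2-fold higher number from compound 1 to compound 3 (0.07 log units; within the scatter)). Hydrogen, bromo and iodo therefore cannot be told apart here, so exchanging one of these atoms for another on this ring does not show a measurable effect on the read-out, and the small step seen with bromo earlier now has a second halogen beside it. No measurement is at hand that could explain this result.

As far as these compounds go, it remains open whether a group of another kind at this place, such as an amine or a carboxylic acid, would produce a step beyond the scatter. The compounds shown also leave open whether a longer chain between the shared core and the amino link would change the number.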